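The source may hold more compounds than are shown below. What is called first, only, known or untested is meant among the compounds shown, and "the series" means these compounds.

Measured in an ADME assay on MCF7-DOX cells (Homo sapiens) for cytotoxicity, read by MTT assay, with a stated time of 48 h; a higher number here means a weaker inhibitor, a lower number a stronger inhibitor:
Compound 1 `COc1cc(OC)c(C(=O)/C=C/c2cccc(F)c2)c(O)c1CC=C(C)C`: 45400 nM
Compound 2 `COc1cc(O)c(C(=O)/C=C/c2cccc(N3CCNCC3)c2)c(OC)c1`: 99200 nM
Compound 3 `CCCc1c(OC)cc(OC)c(C(=O)/C=C/c2cccc(N3CCNCC3)c2)c1O`: > 100000 nM (a limit)

Compound 3 gives > 100000 nM, which is a limit of the assay and not a number. No exact position can therefore be given for it, only the fact that it marks (the limit of > 100000 nM in this assay, at which 1 of the 3 values shown sits).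

Compound 4 `COc1cc(OC)c(C(=O)/C=C/c2cccc(N3CCNCC3)c2)c(O)c1CC=C(C)C` has not yet been measured. It differs from compound 3 by one change: 2-methylprop-1-en-1-yl in place of ethyl on a saturated chain carbon bound to an aromatic carbon. In words, 2-methylprop-1-en-1-yl stands in place of ethyl on a saturated chain carbon bound to an aromatic carbon. The same difference, cut one bond further out, reads propyl to 3-methylbut-2-en-1-yl.

Going by the values given here, only one measured step touches this chain, the entry of propyl in place of hydrogen on an aromatic carbon: a number no lower from compound 2 to compound 3 (the limit leaves the size open). It gives no usable size. The closest guide is compound 1, which also carries 3-methylbut-2-en-1-yl and gives 45400 nM in this assay, although its core differs from that of compound 4 elsewhere. A moderate move towards a lower number is therefore expected, with a real chance of another limit reading.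

The expected step is an at least 1.8-fold lower number from compound 3 to compound 4 (0.25 log units; that floor lies within the scatter). For compound 4 the estimated value is 55000 nM, with an expected range from 20000 nM to 100000 nM.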

Compound 4, half-maximal inhibitory concentration: 99900 nM
Beside the measured number, compound 4's estimate is 1.8-fold (0.26 log units) below it; the measured number falls inside the stated range.
By their numbers in this assay, from the lowest: compound 1; then compounds 2 and 4 (each within the scatter of the next). At a limit, above all of these: compound 3.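

In this assay, adding the 3-methylbut-2-en-1-yl chain gives a 1.0-fold higher number from compound 2 to compound 4 (0.00 log units; within the scatter), so this chain does not separate the two compounds at this position. Compound 3 gives a limit and not a number, so the steps that touch it cannot be read: the limit of > 100000 nM in this assay, at which 1 of the 4 values shown sits. That holds for a number no higher from compound 3 to compound 4 (the limit leaves the size open) as well. With 3-methylbut-2-en-1-yl held in place, piperazin-1-yl in place of fluoro on an aromatic carbon gives a 2.2-fold higher number from compound 1 to compound 4 (0.34 log units; beyond the scatter), a modest step and the first readable one in which this chain stays the same.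

The compounds shown leave open what 3-methylbut-2-en-1-yl does on the core of compound 1, as no partner of compound 1 with hydrogen at this place appears among them.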